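Swapping the aryl group on the acylurea carbonyl

The source may report more compounds than this note shows. Statements on the series, on what has been measured and on what is new or still open speak of the compounds shown alone.

Measured so far:
compound 1, `CN(C(=O)NC(=O)c1cccc(C(F)(F)F)c1)c1nc(C(F)(F)F)c(C(=O)N/N=C/c2ccccc2C(F)(F)F)s1`, 7.69 ug/mL
compound 2, `CN(C(=O)NC(=O)c1c(Cl)cccc1Cl)c1nc(C(F)(F)F)c(C(=O)N/N=C/c2ccccc2C(F)(F)F)s1`, 6.24 ug/mL

In a functional assay on MCF7 cells (Homo sapiens) for inhibition, read by MTT assay, with a stated time of 72 h (on this read-out higher numbers stand for weaker inhibition and lower numbers for stronger inhibition), compound 2 gives the lowest of the two numbers, yet the step of a 1.2-fold lower number from compound 1 to compound 2 (0.09 log units; within the scatter) lies within the usual scatter, so the two compounds cannot be ranked. Compound 3, `CN(C(=O)NC(=O)c1ccccc1F)c1nc(C(F)(F)F)c(C(=O)N/N=C/c2ccccc2C(F)(F)F)s1`, carries the change (2-fluorophenyl in place of 2,6-dichlorophenyl on a carbonyl carbon). Among the compounds with values here, the one measured step that bears on this is the same kind of change at the same carbonyl carbon, from compound 1 to compound 2, and it stayed within the scatter. On that basis no step beyond the scatter is expected in this assay from compound 2 to compound 3, in either direction, and the expected step is a 1.1-fold higher number from compound 2 to compound 3 (0.05 log units; within the scatter). Compound 3 is therefore estimated at 7 ug/mL, with a range from 3.5 ug/mL to 14 ug/mL, resting on the values of compound 1 and compound 2 alone.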

Compound 3, half-maximal inhibitory concentration: 12.2 ug/mL
Estimate against measurement, compound 3: 1.7-fold (0.24 log units) below; the measured number falls inside the stated range.
By their numbers in this assay, from the lowest: compounds 2, 1 and 3 (each within the scatter of the next).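

Within this assay, 2-fluorophenyl is a third aryl group on this carbonyl carbon, and it too gives no step that can be told from the scatter (both a 2.0-fold higher number from compound 2 to compound 3 (0.29 log units; within the scatter) and a 1.6-fold higher number from compound 1 to compound 3 (0.20 log units; within the scatter)). Even the change from 2,6-dichlorophenyl, which carries two chlorine atoms, to a ring with a single fluorine stays within the scatter, though only just, so these three aryl groups cannot be ranked at this position. Nothing available here explains why these compounds give such similar numbers.

All three compounds keep a halogen-bearing or trifluoromethyl-bearing phenyl ring at this position. Going by these compounds, what happens with a phenyl ring carrying an amine or a carboxylic acid, or with a plain methyl group in place of the ring, stays open.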